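Urea-linked aminoindazoles in HOP-92 growth inhibition

The compounds below may be only part of what the source reports. "The series", "measured", "known", "first", "only" and "open" are said of these compounds alone.

Measured so far:
compound 1 `CCCCOc1ccc(NC(=O)n2nc(N)c3ccccc32)cc1` — 18600 nM
compound 2 `Nc1nn(C(=O)Nc2c(F)cccc2F)c2ccccc12` — 17300 nM

In a functional assay on HOP-92 cells (Homo sapiens) for inhibition, read by sulforhodamine B assay, with a stated time of 48 h (a higher number here means a weaker inhibitor of growth, a lower number a stronger inhibitor of growth), compound 1 gives 18600 nM, the highest of the two numbers; compound 2 gives 17300 nM, and the two lie within the scatter of each other. Compound 3 `Nc1nn(C(=O)Nc2ccc(Cc3ccccc3)cc2)c2ccccc12` has not been measured. It differs from compound 1 by benzyl in place of butoxy on an aromatic carbon. Among the compounds with values here, no measured pair shows the effect of such a change, so only a small step in this assay is expected, in either direction or none beyond the scatter. For compound 3 a value of 15000 nM is expected, between 5000 nM and 45000 nM, a step of a 1.2-fold lower number from compound 1 to compound 3 (0.09 log units; within the scatter) estimated from compound 1.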

Compound 3, concentration for 50% growth inhibition: 14200 nM
Compound 3: middle estimate off by 1.1-fold (0.02 log units), on the high side, within the range that was stated.
By their numbers in this assay, from the lowest: compounds 3, 2 and 1 (each within the scatter of the next).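

In this assay the aromatic carbon para to a large group takes benzyl in place of butoxy with a 1.3-fold lower number from compound 1 to compound 3 (0.12 log units; within the scatter) and the two values are not separated. Within the data shown here, at this position, then, exchanging a chain with one hydrogen-bond acceptor for a six-membered aromatic ring of carbon only gives no step that can be read beyond the scatter. Nothing at hand offers an explanation for this result.

Open, on these data alone, is whether an amine or a carboxylic acid on this carbon would give a step beyond the scatter. Also open, as far as these compounds go, is whether a longer chain, such as hexyloxy, would do so.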